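A few compounds are considered here, and "the series" means these few. Any claim that something is new, unique, unknown or untested is made for them only; others in the source may bear on it.

Compound 1 `Cn1cnc(CN2CCN(c3cccc4[nH]c(-c5ccc(C(C)(C)C)cc5)nc34)CC2)c1` gives 33 nM in an assay on isolated protein for displacement of a labelled ligand from Gonadotropin-releasing hormone receptor (Homo sapiens); a lower number here means a stronger inhibitor, a higher number a weaker inhibitor.
Compound 2 `Cc1nc(CN2CCN(c3cccc4[nH]c(-c5ccc(C(C)(C)C)cc5)nc34)CC2)c(C)s1` gives 21 nM in this assay.
Compound 3 `Cc1n[nH]c(C)c1CN1CCN(c2cccc3[nH]c(-c4ccc(C(C)(C)C)cc4)nc23)CC1` gives 68 nM in this assay.

All three share one core and differ only in the small aromatic ring on a saturated chain carbon bound to an amine nitrogen in a ring. Compound 3 has the highest of the three numbers in this assay: a 2.1-fold higher number from compound 1 to compound 3 (0.31 log units; beyond the scatter) and a 3.2-fold higher number from compound 2 to compound 3 (0.51 log units; beyond the scatter), both modest but beyond the scatter, whereas a 1.6-fold lower number from compound 1 to compound 2 (0.20 log units; within the scatter) stays within it. Compound 4 `CCc1nc(CN2CCN(c3cccc4[nH]c(-c5ccc(C(C)(C)C)cc5)nc34)CC2)cn1C` changes that ring once more: 2-ethyl-1-methyl-1H-imidazol-4-yl in place of 3,5-dimethyl-1H-pyrazol-4-yl on a saturated chain carbon bound to an amine nitrogen in a ring. For the measured compounds named here, this largely undoes the change that separates compound 1 from compound 3, returning to a 1-methyl-1H-imidazol-4-yl ring that now carries an additional ethyl, and no measured pair shows what that ethyl does on its own. Because a 2.1-fold higher number from compound 1 to compound 3 (0.31 log units; beyond the scatter) was modest, a modest step downward is expected, a 1.9-fold lower number from compound 3 to compound 4 (0.29 log units; within the scatter). Compound 4 is therefore estimated at 35 nM in this assay, with a range of 15 nM to 90 nM.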

Compound 4, half-maximal inhibitory concentration: 18 nM
Estimate against measurement, compound 4: 1.9-fold (0.29 log units) above; measured number inside the range.
By their numbers in this assay, from the lowest: compounds 4, 2 and 1 (each within the scatter of the next); then compound 3.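

Placing an ethyl on the aromatic carbon of the 1-methyl-1H-imidazol-4-yl ring leaves the number in this assay within the scatter (a 1.8-fold lower number from compound 1 to compound 4 (0.26 log units; within the scatter)), so this ring carries the added ethyl with no measurable loss or gain. Compound 4 also stays within the scatter of the thiazole compound (a 1.2-fold lower number from compound 2 to compound 4 (0.07 log units; within the scatter)) but lies beyond it from the pyrazole (a 3.8-fold lower number from compound 3 to compound 4 (0.58 log units; beyond the scatter)), which leaves compound 3 as the only one of the four set apart from the rest. Nothing measured here explains why the 3,5-dimethyl-1H-pyrazol-4-yl ring stands apart.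

On these data alone, it remains open whether a longer chain such as butyl in place of the ethyl would keep the number in this range. As far as these compounds go, it is equally open whether an amine or a carboxylic acid there would do so.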